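Moving the nitro group on a hydrazone: a cytotoxicity estimate

A few compounds are considered here, and "the series" means these few. Any claim that something is new, unique, unknown or untested is made for them only; others in the source may bear on it.

Measured compounds:
compound 1 `COc1ccccc1-c1nnc(-c2ccc(C(=O)N/N=C/c3ccc([N+](=O)[O-])cc3)cc2)o1` — 203000 nM
compound 2 `COc1ccc(O)c(/C=N/NC(=O)c2ccc(-c3nnc(-c4ccccc4OC)o3)cc2)c1` — 303000 nM

The study examined two hydrazones built on a shared core in an ADME assay on THP-1 cells (Homo sapiens) for cytotoxicity; on this read-out higher numbers stand for weaker inhibition and lower numbers for stronger inhibition. Compound 1 gives 203000 nM and compound 2 gives 303000 nM. Within the data shown here, of the two numbers, compound 1 has the lower one, but the only measured step, a 1.5-fold higher number from compound 1 to compound 2 (0.17 log units; within the scatter), lies within the scatter, so the two compounds cannot be told apart on this read-out.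

The unmeasured compound 3 `COc1ccccc1-c1nnc(-c2ccc(C(=O)N/N=C/c3ccccc3[N+](=O)[O-])cc2)o1` is reached from compound 1 by a single change: 2-nitrophenyl in place of 4-nitrophenyl on a carbon with a double bond to nitrogen. Among the measured compounds shown here, no measured step covers such a shift of a nitro group; the one step in hand, from compound 1 to compound 2, exchanges the whole ring for a different one and still stays within the scatter. On that basis no step beyond the scatter is expected from compound 1 to compound 3 in this assay, so that the expected step is a 1.0-fold higher number from compound 1 to compound 3 (0.01 log units; within the scatter).

Compound 3 is therefore estimated at 210000 nM in this assay, with a range from 100000 nM to 450000 nM.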

Compound 3, half-maximal inhibitory concentration: 161000 nM
Beside the measured number, compound 3's estimate is 1.3-fold (0.12 log units) above it, within the range that was stated.
By their numbers in this assay, from the lowest: compounds 3, 1 and 2 (each within the scatter of the next).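

In this assay, moving the nitro group, with 2-nitrophenyl in place of 4-nitrophenyl on the carbon with a double bond to nitrogen, gives a 1.3-fold lower number from compound 1 to compound 3 (0.10 log units; within the scatter) and so leaves the two isomers indistinguishable on this read-out, a test of the nitro group's location that the earlier pair could not provide. The exchange of 2-hydroxy-5-methoxyphenyl for 2-nitrophenyl at the same place gives a 1.9-fold lower number from compound 2 to compound 3 (0.27 log units; within the scatter), which also stays within the scatter, so none of the three groups at this place can be separated from the others, and no compound shown goes against that reading. Nothing at hand bears on why these steps are so small.

From the compounds shown here alone, the three compounds carry only substituted phenyl groups at this place, so it remains open whether an amine or a carboxylic acid on that ring, or a longer alkyl chain in place of the ring, would produce a step beyond the scatter. Going by these compounds, it also remains open whether the same insensitivity would hold if the 2-methoxyphenyl group at the other end of the shared core were replaced.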